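Swapping fluoro for trifluoromethyl on the carboxy analogue

A few compounds are considered here, and "the series" means these few. Any claim that something is new, unique, unknown or untested is made for them only; others in the source may bear on it.

Measured so far in a functional assay on Hep 3B2 cells (Homo sapiens) for antiproliferative activity, read by MTT assay, with a stated time of 24 h, tested at 11.11 ug/mL; a higher number here means a stronger effect of the compound at the concentration tested, a lower number a weaker effect:
- compound 1 `Cc1c(C(=O)Nc2c(F)cc(-c3cccc(F)c3)cc2F)nc2ccc(F)cc2c1O`: 31.3%
- compound 2 `Cc1c(C(=O)Nc2c(F)cc(-c3cccc(F)c3)cc2F)nc2ccc(C(F)(F)F)cc2c1O`: 36.3%
- compound 3 `Cc1c(C(=O)Nc2c(F)cc(-c3cccc(F)c3)cc2F)nc2ccc(F)cc2c1C(=O)O`: 26.3%

All three share one core and differ only in two groups on it. Compound 3, which carries carboxy instead of hydroxy, has the lowest number of the three, but the step that separates it from the hydroxy compound is a number 5 percentage points lower from compound 1 to compound 3 (within the scatter), and its gap to compound 2 is within the scatter as well, so the three compounds cannot be ranked on these numbers.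

Compound 4 `Cc1c(C(=O)Nc2c(F)cc(-c3cccc(F)c3)cc2F)nc2ccc(C(F)(F)F)cc2c1C(=O)O` has not yet been measured. It differs from compound 3 in this way: trifluoromethyl in place of fluoro on an aromatic carbon

Going by the values given here, one measured step bears on this change, since the same swap was already made on the hydroxy analogue: a number 5 percentage points higher from compound 1 to compound 2 (within the scatter). That step was within the scatter, so no change beyond the scatter is expected in this assay from compound 3 to compound 4 either.

On that basis compound 4 is estimated at 31%, with a range of 19% to 43%, which means an expected step of a number 4.7 percentage points higher from compound 3 to compound 4 (within the scatter).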

Compound 4, a percentage reported as inhibition, at one concentration (the size of the read-out at that concentration, not a potency): 31.2%
Compound 4: middle estimate off by 0.2 percentage points, on the low side, and the stated range covers the measured number.
By their numbers in this assay, from the lowest: compounds 3, 4, 1 and 2 (each within the scatter of the next).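

In this assay, trifluoromethyl in place of fluoro now has a second reading, this time on the carboxy analogue, with a number 4.9 percentage points higher from compound 3 to compound 4 (within the scatter), and it agrees closely with the reading on the hydroxy analogue: the same change on two cores in this assay, a number 5 percentage points higher (within the scatter) from compound 1 to compound 2 and a number 4.9 percentage points higher (within the scatter) from compound 3 to compound 4, 0.1 percentage points apart, within the scatter of two such steps

Carboxy in place of hydroxy also has a second reading, now with trifluoromethyl on the shared core, with a number 5.1 percentage points lower from compound 2 to compound 4 (within the scatter), and the two readings again agree: the same change on two cores in this assay, a number 5 percentage points lower (within the scatter) from compound 1 to compound 3 and a number 5.1 percentage points lower (within the scatter) from compound 2 to compound 4, 0.1 percentage points apart, within the scatter of two such steps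

Across these four compounds, then, the step for each swap stays the same whichever group is present at the other place, although every step lies within the scatter, so neither swap is shown to change the number at all.

The compounds shown leave open whether an amine or a methoxy group on this aromatic carbon would move the number in this assay beyond the scatter. Going by these compounds, each compound also has a reading at only one concentration, so the size of the effect at that concentration says nothing about potency, which remains open for all four.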